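Swapping a Nitrile-Bearing Ring for Naphthalene on the Sulfonamide

The source may report more compounds than this note shows. Statements on the series, on what has been measured and on what is new or still open speak of the compounds shown alone.

Measured compounds:
compound 1 `COc1n[nH]c2ncc(-c3nc(-c4c(F)ccc(NS(=O)(=O)c5cccc(Cl)c5)c4F)no3)cc12` gives 29 nM
compound 2 `COc1n[nH]c2ncc(-c3cn(-c4c(Cl)ccc(NS(=O)(=O)c5cccc(Cl)c5)c4Cl)nn3)cc12` gives 413 nM
compound 3 `COc1n[nH]c2ncc(-c3cn(-c4c(F)ccc(NS(=O)(=O)c5cccc(C#N)c5)c4F)nn3)cc12` gives 3.3 nM

In an assay on Sf9 cells for inhibition of mitogen-activated protein kinase kinase kinase 20 (Homo sapiens), read by ADP-Glo, with a stated time of 30 min (on this read-out lower numbers stand for stronger inhibition and higher numbers for weaker inhibition), compound 3 stands at the lowest number of the three, and its gaps to compound 1 and to compound 2 are both beyond the scatter, so it is the strongest inhibitor shown. Compound 4 `COc1n[nH]c2ncc(-c3cn(-c4c(F)ccc(NS(=O)(=O)c5ccc6ccccc6c5)c4F)nn3)cc12` keeps everything of compound 3 except one change: naphthalen-2-yl in place of 3-cyanophenyl on a sulfonyl sulfur. Among the compounds with values here, no measured pair shows this exact swap, so the expectation rests on compound 3 alone. Replacing the nitrile-bearing ring by the larger two-ring group is expected to weaken inhibition somewhat, by about a 3.6-fold higher number from compound 3 to compound 4 (0.56 log units; beyond the scatter). Compound 4 is therefore estimated at 12 nM, within a range from 3 nM to 50 nM.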

Compound 4, half-maximal inhibitory concentration: 4.5 nM
Compound 4: middle estimate off by 2.7-fold (0.43 log units), on the high side; the measured number falls inside the stated range.
By their numbers in this assay, from the lowest: compounds 3 and 4 (each within the scatter of the next); then compound 1; then compound 2.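

In this assay the step of a 1.4-fold higher number from compound 3 to compound 4 (0.13 log units; within the scatter) shows that, on a sulfonyl sulfur, the two-ring naphthalen-2-yl can stand in for 3-cyanophenyl with no real change in the number. Strong inhibition in this pair therefore does not depend on the nitrile, and this position accepts a larger group made of carbon only. Nothing measured here explains why the two groups read alike.

From the compounds shown here alone, whether a small methyl group, or a phenyl ring carrying an amine or a carboxylic acid, would hold the number at this position remains open.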